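Aryl swap on the fused core: solubility notes

The source may hold more compounds than are shown below. What is called first, only, known or untested is meant among the compounds shown, and "the series" means these compounds.

Compound 2 `Cc1cc(NCc2ccccn2)n2ncc(-c3ccc(C#N)cc3)c2n1` carries a 4-cyanophenyl on the shared core. In a physicochemical assay for solubility, read by HPLC, using the shake flask method, measured as kinetic solubility, with a stated time of 2 h, at pH 7.4 (on this read-out higher numbers stand for higher solubility and lower numbers for lower solubility), compound 2 gives < 5000 nM, which is a limit of the assay and not a number. Compound 1 `Cc1cc(NCc2ccccn2)n2ncc(-c3ccc(F)cc3)c2n1` likewise sits at a limit. In this assay compound 1 gives < 5000 nM. The step that the two limits leave unreadable from compound 1 to compound 2 therefore cannot be sized, and the limit of < 5000 nM in this assay, at which 2 of the 2 values shown sit, is the whole of the measured evidence. Compound 3 `Cc1cc(NCc2ccccn2)n2ncc(-c3cccc(Cl)c3)c2n1` differs by 3-chlorophenyl in place of 4-cyanophenyl on an aromatic carbon. No readable measured step bears on this change. The estimate for compound 3 in this assay is 2000 nM, with a range of 300 nM to 5000 nM. That expectation amounts to a step that the limit leaves unreadable from compound 2 to compound 3.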

Compound 3, solubility: < 5000 nM
Compound 3 gave a limit, no number (the forecaster's own chance of this, stated with the estimate: 85%); the middle value is on the limit's open side.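

Among the compounds shown here, compound 3 is also a limit and not a number, so no step among compound 1, compound 2 and compound 3 can be read: the limit of < 5000 nM in this assay, at which 3 of the 3 values shown sit. The compounds shown leave open where each one's solubility actually lies in this assay, and whether these aryl changes shift it at all.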